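A few compounds are considered here, and "the series" means these few. Any claim that something is new, unique, unknown or untested is made for them only; others in the source may bear on it.

Compound 1 `O=C(CCCCOc1ccccc1)OCC1COCCOCCOCCOCCOCCO1`: in a functional assay on HBL-100 cells (Homo sapiens) for inhibition, read by sulforhodamine B assay, with a stated time of 48 h (a higher number here means a weaker inhibitor of growth, a lower number a stronger inhibitor of growth), compound 1 reaches only the assay limit > 100000 nM, a limit and not a number.
Compound 2 `O=C(/C=C/c1ccccc1)OCC1COCCOCCOCCOCCOCCO1`: compound 2 gives 57000 nM in this assay.
Compound 3 `O=C(CCCCc1ccccc1)OCC1COCCOCCOCCOCCOCCO1`: compound 3 gives 69000 nM in this assay.

Compound 3 holds the higher of the two numbers in this assay; compound 2 is nearest, with a 1.2-fold higher number from compound 2 to compound 3 (0.08 log units; within the scatter). Compound 1 sits at a limit (the limit of > 100000 nM in this assay, at which 1 of the 3 values shown sits), so an at least 1.4-fold lower number from compound 1 to compound 3 (0.16 log units; that floor lies within the scatter) has only a floor. Compound 4 `O=C(CCCCC1CCCCC1)OCC1COCCOCCOCCOCCOCCO1` differs from compound 3 by cyclohexyl in place of phenyl on a saturated chain carbon, four bonds along the chain from a carbonyl carbon. Among the compounds with values here, no measured step puts cyclohexyl in place of phenyl; the closest, an at least 1.4-fold lower number from compound 1 to compound 3 (0.16 log units; that floor lies within the scatter), alters the same chain carbon and lies within the scatter, as does a 1.2-fold higher number from compound 2 to compound 3 (0.08 log units; within the scatter). No step beyond the scatter is therefore expected in this assay. Compound 4 is expected near 70000 nM, between 30000 nM and 150000 nM, an expected step of a 1.0-fold higher number from compound 3 to compound 4 (0.01 log units; within the scatter).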

Compound 4, concentration for 50% growth inhibition: 72000 nM
Compound 4: the middle estimate sits 1.0-fold (0.01 log units) below what was measured; low and high end bracket the measured number.
By their numbers in this assay, from the lowest: compounds 2, 3 and 4 (each within the scatter of the next). At a limit, above all of these: compound 1.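

Cyclohexyl in place of phenyl at this chain end gives no step beyond the scatter in this assay: a 1.0-fold higher number from compound 3 to compound 4 (0.02 log units; within the scatter), and against the 2-phenylethenyl ester the same holds: a 1.3-fold higher number from compound 2 to compound 4 (0.10 log units; within the scatter). So on this saturated chain carbon, an aromatic ring is not needed to keep the number where compound 3 has it. Against compound 1 only a floor can be read: an at least 1.3-fold lower number from compound 1 to compound 4 (0.14 log units; that floor lies within the scatter). Compound 1 stands at a limit: the limit of > 100000 nM in this assay, at which 1 of the 4 values shown sits.

Open, from the compounds shown here alone, is whether an amine or a carboxylic acid in place of the ring, or a longer chain, would give a step beyond the scatter in this assay.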